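Amide nitrogen substituent variation at Toll-like receptor 2

A few compounds are considered here, and "the series" means these few. Any claim that something is new, unique, unknown or untested is made for them only; others in the source may bear on it.

Compound 3 `CCCCCCCCCCCC(=O)OC[C@H](CSC[C@@H](N)C(=O)NC(C)c1ccccc1)OC(=O)CCCCCCCCCCC` gives 9900 nM in an assay on HEK293 cells for agonist activity at Toll-like receptor 2 (Homo sapiens); on this read-out higher numbers stand for an effect only at larger amounts of compound and lower numbers for an effect already at smaller amounts. Among the three numbers at hand it stands second highest. Compound 1 `CCCCCCCCCCCC(=O)OC[C@H](CSC[C@@H](N)C(=O)NC(C)(C)CO)OC(=O)CCCCCCCCCCC` gives 15500 nM in this assay, and the step of a 1.6-fold lower number from compound 1 to compound 3 (0.19 log units; within the scatter) lies within the scatter. Compound 2 `CCCCCCCCCCCC(=O)OC[C@H](CSC[C@@H](N)C(=O)NC1(CO)CC1)OC(=O)CCCCCCCCCCC` gives 265 nM, and the step of a 37-fold higher number from compound 2 to compound 3 (1.57 log units; beyond the scatter) is large; the step of a 58-fold lower number from compound 1 to compound 2 (1.77 log units; beyond the scatter) is large as well, so the only movement beyond the scatter in this set comes with the 1-(hydroxymethyl)cyclopropyl group of compound 2.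

Compound 4 `CCCCCCCCCCCC(=O)OC[C@H](CSC[C@@H](N)C(=O)NC(CC)COC)OC(=O)CCCCCCCCCCC` differs from compound 3 at the same position: 1-(methoxymethyl)propyl in place of 1-phenylethyl on an amide-type nitrogen. Both measured steps at this nitrogen bear on it. The entering group is acyclic and branched at the carbon attached to nitrogen, as is the 1-(hydroxymethyl)-1-methylethyl group of compound 1, and the acyclic groups of compounds 1 and 3 gave numbers within the scatter of each other. For the measured compounds named here, the one large step belongs to a ring-bearing group that compound 4 does not carry. The expected step in this assay is therefore none beyond the scatter, a 1.1-fold lower number from compound 3 to compound 4 (0.04 log units; within the scatter). For compound 4 the estimate is 9000 nM, with a range from 2500 nM to 35000 nM.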

Compound 4, half-maximal effective concentration: 71.8 nM
Compound 4: middle estimate off by 130-fold (2.10 log units), on the high side; the whole stated range lies above it.
By their numbers in this assay, from the lowest: compound 4; then compound 2; then compounds 3 and 1 (each within the scatter of the next).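

At this amide-type nitrogen, this assay does not divide the groups into ring-bearing and acyclic ones: 1-(methoxymethyl)propyl, which carries no ring, gives (a 140-fold lower number from compound 3 to compound 4 (2.14 log units; beyond the scatter)) and (a 220-fold lower number from compound 1 to compound 4 (2.33 log units; beyond the scatter)), so a ring is not required for a low number here. The same group also goes beyond the 1-(hydroxymethyl)cyclopropyl group (a 3.7-fold lower number from compound 2 to compound 4 (0.57 log units; beyond the scatter)), which leaves compound 4 lowest of the four, while the acyclic group of compound 1 goes against any reading that an acyclic group alone gives a low number. No measurement shown accounts for these steps.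

The step from compound 3 to compound 4 removes the aromatic ring and brings in a hydrogen-bond acceptor at once, so the compounds shown do not separate the two changes, nor do they show whether the methoxymethyl arm or the ethyl arm of the entering group carries the step. On these data alone, a 1-(hydroxymethyl)propyl group, a 1-methylpropyl group or an aminomethyl arm at this nitrogen would bear on that, and the configuration at the branched carbon of 1-(methoxymethyl)propyl also remains open.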